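The source may hold more compounds than are shown below. What is called first, only, known or untested is meant among the compounds shown, and "the series" means these compounds.

In a physicochemical assay for lipophilicity, read by HPLC, at pH 7.4 (a lower number here means a more polar compound, a higher number a more lipophilic compound), three compounds have been measured so far. Compound 1 `CNCc1cc(-c2cccnc2F)n(S(=O)(=O)c2cccnc2)c1` gives -0.85, and compound 2 `CNCc1cc(-c2cccnc2F)n(S(=O)(=O)c2cccs2)c1` gives -0.69. Compound 3 `CNCc1cn(S(=O)(=O)c2cccc(C)n2)c(-c2cccnc2F)c1F` gives 0.71, the highest of the three numbers and beyond the scatter from each of the other two. It differs from both in more than one place, so these gaps do not isolate any single change.

The next compound is compound 4 `CNCc1cn(S(=O)(=O)c2cncc(C)c2)c(-c2cccnc2F)c1F`, which has the same atoms as compound 3, joined differently. The change is 5-methylpyridin-3-yl in place of 6-methylpyridin-2-yl on a sulfonyl sulfur and it amounts to 5-methylpyridin-3-yl in place of 6-methylpyridin-2-yl on a sulfonyl sulfur.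

Among the compounds with values here, only one measured step bears on this swap: a number 0.16 log units higher from compound 1 to compound 2 (within the scatter), which is also a change of group on a sulfonyl sulfur and stays within the scatter. Within the data shown here, it involves a different pair of groups, and no measurement yet compares the two groups at issue here, so it offers only modest guidance. On that basis, no shift beyond the scatter is expected in this assay, and the expected change is a number 0.16 log units lower from compound 3 to compound 4 (within the scatter). Compound 4 is therefore expected at 0.55, with an estimated range from 0.1 to 1.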

Compound 4, distribution coefficient: 0.61
Estimate against measurement, compound 4: 0.06 log units below; low and high end bracket the measured number.
By their numbers in this assay, from the lowest: compounds 1 and 2 (each within the scatter of the next); then compounds 4 and 3 (each within the scatter of the next).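

Within the data shown here, with the atom counts unchanged, moving from 6-methylpyridin-2-yl to 5-methylpyridin-3-yl on the sulfonyl sulfur gives a number 0.10 log units lower from compound 3 to compound 4 (within the scatter) in this assay, the first direct comparison of these two groups. This is a second change of group at this position, alongside a number 0.16 log units higher from compound 1 to compound 2 (within the scatter), and it comes on a different core; neither of these two steps goes beyond the scatter, and no listed step at this position goes against that, although the pattern rests on these two pairs alone. No evidence is available that explains the size of this step.

The compounds shown leave open whether the same change between the two methylpyridinyl groups would give a similar step on the core of compound 1, and the gaps between that pair and compounds 3 and 4 cannot be assigned to any single change. They also leave open whether a group of a different kind on the sulfonyl sulfur, such as a benzoic acid or an aminomethylphenyl group, would remain within the scatter of compound 3 in this assay.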